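A few compounds are considered here, and "the series" means these few. Any claim that something is new, unique, unknown or untested is made for them only; others in the source may bear on it.

Measured so far in a functional assay on the whole organism with Mus musculus as the target, with a stated time of 1 h; a higher number here means that more compound is needed for the effect, a lower number that less compound is needed:
- compound 1 `Cc1ccccc1-c1nnc(NN)s1`: compound 1 gives 30 mg/kg
- compound 2 `Cc1ccccc1-c1nnc(NNC(C)C)s1`: compound 2 gives 54 mg/kg
- compound 3 `Cc1ccccc1-c1nnc(NNc2ccccc2)s1`: compound 3 gives only a limit, > 100 mg/kg

Compound 3 stands at the top of the measured range, and its value is a limit of this assay rather than a number (the limit of > 100 mg/kg in this assay, at which 1 of the 3 values shown sits). Three steps are known among the measured compounds, all at the amine nitrogen of the hydrazine: a 1.8-fold higher number from compound 1 to compound 2 (0.26 log units; within the scatter); an at least 3.3-fold higher number from compound 1 to compound 3 (0.52 log units; beyond the scatter); an at least 1.8-fold higher number from compound 2 to compound 3 (0.26 log units; that floor lies within the scatter). Among the compounds with values here, only the step with phenyl in place of hydrogen clearly exceeds the scatter, and it ends at the limit.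

Compound 4 `Clc1ccccc1-c1nnc(NNc2ccccc2)s1` differs from compound 3 in a different part of the molecule: chloro in place of methyl on an aromatic carbon. Within the data shown here, no measured step touches this six-membered ring, so none of the three steps bears on this change directly; the sole measured guide is that compound 3, carrying the same phenyl hydrazine, already sits at the limit in this assay. The expectation is therefore no step beyond the scatter, with compound 4 most likely also ending as a limit. The expected step is a step that the limit leaves unreadable from compound 3 to compound 4. Compound 4 is estimated at 150 mg/kg, with a range from 60 mg/kg to 400 mg/kg.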

Compound 4, dose for half-maximal effect: > 200 mg/kg
Compound 4 gave a limit, no number (the forecaster's own chance of this, stated with the estimate: 70%); middle value at least 1.3-fold (0.12 log units) from the limit.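

Within the data shown here, compound 3 and compound 4 both end as limits in this assay, and no step between them can be read. The compounds shown leave open whether chloro in place of methyl on an aromatic carbon changes the dose needed at all, in either direction, while phenyl stays on the amine nitrogen.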